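A few compounds are considered here, and "the series" means these few. Any claim that something is new, unique, unknown or untested is made for them only; others in the source may bear on it.

Of the compounds shown here, three built on one shared core have been measured in an ADME assay on HEL cells (Homo sapiens) for cytotoxicity, with a stated time of 3 days; on this read-out higher numbers stand for lower toxicity in this test and lower numbers for higher toxicity in this test. Compound 1 `C=Cc1ccc(-c2cc(C)c3ncc(CSCCc4ccccc4)n3c2)cc1` gives 14 ug/mL. Compound 2 `Cc1cc(N2CCCC2)cn2c(CSCCc3ccccc3)cnc12` gives 12 ug/mL, the lowest of the three numbers, though its distance from compound 1 lies within the scatter. Compound 3 `Cc1cc(N2CCCC2=O)cn2c(CSCCc3ccccc3)cnc12` gives 89 ug/mL. The single-point steps among them are a 1.2-fold lower number from compound 1 to compound 2 (0.07 log units; within the scatter), a 6.4-fold higher number from compound 1 to compound 3 (0.80 log units; beyond the scatter) and a 7.4-fold higher number from compound 2 to compound 3 (0.87 log units; beyond the scatter).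

Compound 4 `Cc1cc(Sc2ccc(O)cc2)cn2c(CSCCc3ccccc3)cnc12` has not yet been tested in this assay. It differs from compound 2 in one place: (4-hydroxyphenyl)sulfanyl in place of pyrrolidin-1-yl on an aromatic carbon. Within the data shown here, two measured steps bear on this exchange. Replacing pyrrolidin-1-yl by 2-oxopyrrolidin-1-yl gave the modest rise seen in a 7.4-fold higher number from compound 2 to compound 3 (0.87 log units; beyond the scatter), but compound 4 carries no 2-oxopyrrolidin-1-yl. Swapping between pyrrolidin-1-yl and 4-vinylphenyl stayed within the scatter, as a 1.2-fold lower number from compound 1 to compound 2 (0.07 log units; within the scatter) shows. Because a 1.2-fold lower number from compound 1 to compound 2 (0.07 log units; within the scatter) was so small, compound 4 is expected to move only by a 1.5-fold higher number from compound 2 to compound 4 (0.18 log units; within the scatter). Compound 4 is therefore estimated at 18 ug/mL, with a likely range from 7 ug/mL to 45 ug/mL.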

Compound 4, half-maximal cytotoxic concentration: 100 ug/mL
Beside the measured number, compound 4's estimate is 5.6-fold (0.74 log units) below it; measured number outside the range, above it.
By their numbers in this assay, from the lowest: compounds 2 and 1 (each within the scatter of the next); then compounds 3 and 4 (each within the scatter of the next).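

In this assay, this position can give a high number with more than one kind of group: (4-hydroxyphenyl)sulfanyl in place of pyrrolidin-1-yl gives a clear rise (an 8.3-fold higher number from compound 2 to compound 4 (0.92 log units; beyond the scatter)), so the rise seen earlier is not tied to 2-oxopyrrolidin-1-yl alone. A six-membered aromatic ring at this place does not by itself hold the number low either, as compound 1 and compound 4 both carry one, yet their groups are far apart (a 7.1-fold higher number from compound 1 to compound 4 (0.85 log units; beyond the scatter)), while the two groups at the high end cannot be told apart (a 1.1-fold higher number from compound 3 to compound 4 (0.05 log units; within the scatter)). No measurement on hand explains why these groups differ.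

Going by these compounds, it remains open whether the sulfur link or the hydroxyl goes with the higher number. A phenylsulfanyl group without the hydroxyl, or one with a carboxylic acid in its place, would help separate the two.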